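A Trifluoromethyl Swap on a Poorly Soluble Scaffold

A few compounds are considered here, and "the series" means these few. Any claim that something is new, unique, unknown or untested is made for them only; others in the source may bear on it.

Compound 2 `CCc1ccccc1Nc1ncc2cc(Oc3ccnc(C(=O)NC)c3)ccc2n1` was tested in a physicochemical assay for solubility, at pH 7 (on this read-out lower numbers stand for lower solubility and higher numbers for higher solubility), and returned < 1000 nM, which is a limit of the assay rather than a number. Compound 1 `CNC(=O)c1cc(Oc2ccc3nc(Nc4cccc(C(C)(C)C)c4)cnc3c2)ccn1` likewise gives < 1000 nM, a limit. Compound 3 `CNC(=O)c1cc(Oc2ccc3nc(Nc4ccccc4Oc4ccccc4)ncc3c2)ccn1` also gives < 1000 nM, again a limit. The step that the two limits leave unreadable from compound 2 to compound 3 therefore cannot be read, because of the limit of < 1000 nM in this assay, at which 3 of the 3 values shown sit. Compound 4 `CNC(=O)c1cc(Oc2ccc3nc(Nc4cccc(C(F)(F)F)c4)ncc3c2)ccn1` differs from compound 2 by 3-(trifluoromethyl)phenyl in place of 2-ethylphenyl on a nitrogen on an aromatic ring. Going by the values given here, no measured step bears readably on this change, and the only comparable step is the unreadable one, so the expected step is a step that the limit leaves unreadable from compound 2 to compound 4, most likely leaving the result at the same limit. Compound 4 is thus expected to show 500 nM, with a range from 100 nM to 1500 nM.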

Compound 4, solubility: < 1000 nM
Compound 4: only a limit was reported; the forecaster's own chance of this, stated with the estimate: 80%; the middle value does not contradict the limit.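

Compound 4 and compound 2 both sit at a limit, not a number, so the step between them cannot be read: the limit of < 1000 nM in this assay, at which 4 of the 4 values shown sit. The compounds shown leave open how soluble each one actually is, and whether this swap changes solubility at all.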